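The compounds below may be only part of what the source reports. "The series", "measured", "known", "first", "only" and "open" are said of these compounds alone.

Working notes on cytotoxicity in the series. In an ADME assay on BJ cells (Homo sapiens) for cytotoxicity, read by CellTiter-Glo and resazurin assay, with a stated time of 72 h (a higher number here means that more compound is needed for the effect, a lower number that less compound is needed), compound 1 `CC(C)COc1cccc(-c2ccc(C(=O)N(Cc3cccc(OCCCCCC(=O)O)c3)C(C)C)cc2)c1` reaches only the assay limit, recorded as > 26000 nM and nothing more. Compound 2 `CCOC(=O)CCCCCOc1cccc(CN(C(=O)c2ccc(-c3cccc(OCC(C)C)c3)cc2)C(C)C)c1` likewise gives only a limit in this run, namely > 26000 nM with no number behind it. The step that the two limits leave unreadable from compound 1 to compound 2 is therefore unreadable; its change is ethyl in place of hydrogen on an oxygen next to a carbonyl group. Compound 2 thus stands at the limit together with compound 1, as the limit of > 26000 nM in this assay, at which 2 of the 2 values shown sit, records. Within the data shown here, compound 3 `CCOC(=O)CCCCCOc1cccc(CN(C(=O)c2ccc(-c3cccc(F)c3)cc2)C(C)C)c1` differs from compound 2 by fluoro in place of isobutoxy on an aromatic carbon; this change sits elsewhere than the one step already measured, so no measured step bears on it directly. With both known values at the limit, no step beyond the scatter is expected, and the expected step that the limit leaves unreadable from compound 2 to compound 3 is accordingly small. In this assay compound 3 is estimated at 30000 nM, within the range 10000 nM to 100000 nM, most likely reported again only as a limit.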

Compound 3, half-maximal effective concentration: > 26000 nM
Compound 3: a limit, no number; the forecaster's own chance of this, stated with the estimate: 80%; the middle value does not contradict the limit.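

Among these compounds, compound 3, like compound 2, gives only a limit in this assay, so no step between compound 2 and compound 3 can be read. The compounds shown leave open whether either change alters cytotoxicity at all, since all of them rest at one mark: the limit of > 26000 nM in this assay, at which 3 of the 3 values shown sit.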